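The source may report more compounds than this note shows. Statements on the series, on what has been measured and on what is new or still open speak of the compounds shown alone.

Three compounds have been measured in a functional assay on PC-3 cells (Homo sapiens) for cytotoxicity, read by MTT assay, with a stated time of 72 h; a lower number here means a stronger inhibitor, a higher number a weaker inhibitor:

Compound 1 `N#Cc1ccc(/C=N/NC(=O)Nc2cc3c(Nc4ccc(F)c(Cl)c4)ncnc3cc2O[C@H]2CCOC2)cc1`: 28100 nM
Compound 2 `O=C(N/N=C/c1ccc([N+](=O)[O-])cc1)Nc1cc2c(Nc3ccc(F)c(Cl)c3)ncnc2cc1O[C@H]1CCOC1`: 33500 nM
Compound 3 `COc1ccc(/C=N/NC(=O)Nc2cc3c(Nc4ccc(F)c(Cl)c4)ncnc3cc2O[C@H]2CCOC2)c(OC)c1OC`: 25600 nM

Compound 2 cannot be told apart from the other two: the data show a 1.2-fold higher number from compound 1 to compound 2 (0.08 log units; within the scatter) and a 1.3-fold lower number from compound 2 to compound 3 (0.12 log units; within the scatter). Compound 4 `COc1cc2ncnc(Nc3ccc(F)c(Cl)c3)c2cc1NC(=O)N/N=C/c1ccc([N+](=O)[O-])cc1` has not yet been measured. It differs from compound 2 in one place, with methyl in place of oxolan-3-yl on an oxygen on an aromatic ring.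

Among the measured compounds shown here, no measured step touches this place, since compound 1, compound 2 and compound 3 all carry oxolan-3-yl there. The two steps above and a 1.1-fold lower number from compound 1 to compound 3 (0.04 log units; within the scatter) all change a different part of the structure, and all lie within the scatter. They show a flat set of numbers for those changes, but they give no direct reading on the group now being replaced. The data therefore support no direction, and no step beyond the scatter is expected, though with real uncertainty. The expected size of the change is a 1.1-fold lower number from compound 2 to compound 4 (0.05 log units; within the scatter). In this assay, compound 4 is estimated at 30000 nM, with an expected range from 12000 nM to 70000 nM.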

Compound 4, half-maximal inhibitory concentration: 32400 nM
Estimate against measurement, compound 4: 1.1-fold (0.03 log units) below; the range from low to high includes it.
By their numbers in this assay, from the lowest: compounds 3, 1, 4 and 2 (each within the scatter of the next).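

Among the compounds shown here, until this result, every compound carried oxolan-3-yl on the oxygen on the aromatic ring, so the position itself had no reading. In this assay, replacing that group with methyl now gives one (a 1.0-fold lower number from compound 2 to compound 4 (0.01 log units; within the scatter)), and compound 2 and compound 4 cannot be told apart. With the 4-nitrophenyl group held fixed, the five-membered non-aromatic ring, its hydrogen-bond acceptor and its defined stereocentre can all leave this oxygen without a step beyond the scatter, and nothing available accounts for this result.

This single pair leaves open whether (oxolan-3-yl)oxy and methoxy would also be indistinguishable in compounds bearing 4-cyanophenyl or 2,3,4-trimethoxyphenyl in place of 4-nitrophenyl. It also leaves open whether a longer chain ending in an amine or a carboxylic acid on the same oxygen would stay within the scatter of these compounds in this assay or move the number in either direction.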